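Thioether in Place of Propoxy on a Channel Antagonist

This account rests on a few compounds, and the source may have more. Where it says the series, first, only, none or still open, it means among the compounds named here.

Compound 1 `CCCN(CCC)c1cc(C(F)(F)F)ccc1CNC(=O)C(C)c1ccc(NS(C)(=O)=O)c(F)c1` gives 0.3 nM in an assay on CHO cells for antagonist activity at transient receptor potential cation channel subfamily V member 1 (Homo sapiens), read by FLIPR; on this read-out higher numbers stand for weaker inhibition and lower numbers for stronger inhibition
Compound 2 `CC(C(=O)NCc1ccc(C(F)(F)F)cc1N1CCCCCC1)c1ccc(NS(C)(=O)=O)c(F)c1` gives 1.6 nM in this assay
Compound 3 `CCCOc1cc(C(F)(F)F)ccc1CNC(=O)C(C)c1ccc(NS(C)(=O)=O)c(F)c1` gives 2 nM in this assay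

Compound 3 has the highest number of the three: its gap to compound 2 is within the scatter (a 1.3-fold higher number from compound 2 to compound 3 (0.10 log units; within the scatter)), while compound 1 reaches a clearly lower number (a 6.7-fold higher number from compound 1 to compound 3 (0.82 log units; beyond the scatter)). Compound 4 `CC(C)CCSc1cc(C(F)(F)F)ccc1CNC(=O)C(C)c1ccc(NS(C)(=O)=O)c(F)c1` differs from compound 3 in one place: isopentylsulfanyl in place of propoxy on an aromatic carbon. Going by the values given here, no measured step exchanges oxygen for sulfur or lengthens the chain at this position; the measured steps only show that the group there can move the number beyond the scatter, as in a 5.3-fold higher number from compound 1 to compound 2 (0.73 log units; beyond the scatter). With no pointer in either direction, no step beyond the scatter is expected, no change at the digits printed from compound 3 to compound 4 (within the scatter). Compound 4 is therefore estimated at 2 nM, between 0.5 nM and 8 nM.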

Compound 4, inhibition constant: 1.4 nM
Compound 4: the middle estimate sits 1.4-fold (0.15 log units) above what was measured, and the stated range covers the measured number.
By their numbers in this assay, from the lowest: compound 1; then compounds 4, 2 and 3 (each within the scatter of the next).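

Putting isopentylsulfanyl in place of propoxy keeps the number in this assay within the scatter (a 1.4-fold lower number from compound 3 to compound 4 (0.15 log units; within the scatter)), so at this position the linking atom and chain length changed together without a clear shift. Compound 4 also stays within the scatter of the azepan-1-yl compound (a 1.1-fold lower number from compound 2 to compound 4 (0.06 log units; within the scatter)), while dipropylamino keeps its clear lead (a 4.7-fold higher number from compound 1 to compound 4 (0.67 log units; beyond the scatter)). The data shown offer no explanation for this pattern.

Going by these compounds, the separate contributions of sulfur and chain length remain open, and propylsulfanyl or isopentyloxy would pull them apart. On these data alone, whether a smaller amine such as dimethylamino would match dipropylamino is also open.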